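Ring size at the aniline amine in a kinase series

The source may hold more compounds than are shown below. What is called first, only, known or untested is meant among the compounds shown, and "the series" means these compounds.

Compound 1: `CCC(=O)Nc1cccc(Oc2nc(Nc3ccc(N(C)C)cc3OC)ncc2Cl)c1` — 15%
Compound 2: `CCC(=O)Nc1cccc(Oc2nc(Nc3ccc(N4CCCC4)cc3OC)ncc2Cl)c1` — "not active" (no number reported)

In an assay on isolated protein for inhibition of NUAK family SNF1-like kinase 2 (Homo sapiens), read by ADP-Glo, with a stated time of 60 min, tested at 10 uM, in the presence of a further agent that is not named here (on this read-out lower numbers stand for less inhibition and higher numbers for more inhibition at the one concentration tested (going by the name of the read-out)), compound 1 gives 15%. In this assay compound 2 is reported as "not active" (no number reported), so no single number stands for compound 2, and its two values with compound 1 both point to weak inhibition at the one concentration tested. Compound 3, `CCC(=O)Nc1cccc(Oc2nc(Nc3ccc(N4CCC(C)CC4)cc3OC)ncc2Cl)c1`, differs from compound 2 by 4-methylpiperidin-1-yl in place of pyrrolidin-1-yl on an aromatic carbon. Among the measured compounds shown here, no measured step exists for this change, so the account expects at most a small shift in this assay, in either direction or none beyond the scatter. Compound 3 is estimated to give 8%, ranging from 0% to 25%.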

Compound 3, a percentage reported as inhibition, at one concentration (the size of the read-out at that concentration, not a potency): "not active" (no number reported)
The entry for compound 3 holds no number; there is nothing to compare the estimate with.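

In this assay compound 2 and compound 3 both carry no number, so no step can be read between them. The compounds shown leave open whether pyrrolidin-1-yl and 4-methylpiperidin-1-yl differ at all in inhibition. No evidence at hand bears on this result.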